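A Methyl Added to an Inactive Hydroxyurea

A few compounds are considered here, and "the series" means these few. Any claim that something is new, unique, unknown or untested is made for them only; others in the source may bear on it.

compound 1 `CC(C)C(NC(=O)NO)C(=O)NC1CCCCC1` — > 100000 nM
compound 2 `CCC(C)C1NC(=O)N(C2CCCCC2)C1=O` — > 200000 nM

In a functional assay on CCRF-CEM cells (Homo sapiens) for inhibition (a higher number here means a weaker inhibitor, a lower number a stronger inhibitor), compound 1 gives > 100000 nM, which is a limit of the assay and not a number, so compound 1 stands at the weak end of what was recorded, with no measured inhibition at all. Compound 2, built on a different core, gives > 200000 nM in this assay, again a limit rather than a number. Among the measured compounds shown here, no step between these two measured compounds is available, so their two values only show that neither reached measurable inhibition.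

Compound 3 `CCC(C)C(NC(=O)NO)C(=O)NC1CCCCC1` is not yet measured. It differs from compound 1 by methyl in place of hydrogen on a saturated chain carbon, three bonds along the chain from an amide-type nitrogen and a carbonyl carbon. With only limits to build on, the expectation is that such a small change produces no step beyond the scatter, and compound 3 is expected to remain unmeasurable; the expected step is a step that the limit leaves unreadable from compound 1 to compound 3. Compound 3 is estimated at 150000 nM, within 50000 nM to 500000 nM, most likely reported only as a limit.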

Compound 3, half-maximal inhibitory concentration: 153000 nM
Compound 3: the middle estimate sits 1.0-fold (0.01 log units) below what was measured; the measured number falls inside the stated range.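

The step from compound 1 to compound 3 cannot be read: in this assay compound 1 gives > 100000 nM, which is a limit and not a number. On these data alone, whether methyl in place of hydrogen at this place changes inhibition at all, and by how much, remains open.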